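A few compounds are considered here, and "the series" means these few. Any claim that something is new, unique, unknown or untested is made for them only; others in the source may bear on it.

Measured compounds:
compound 1 `CC(C)=CCC/C(C)=C/CC1Cc2c(OCCCOc3ccc(Cl)cc3)cc(=O)n(CCCO)c2CC1(C)C` — 25.2%
compound 2 `COc1cccc(NC(=O)Oc2cc(=O)n(CCCO)c3c2CC(C/C=C(\C)CCC=C(C)C)C(C)(C)C3)c1` — 47%
compound 3 `CC(C)=CCC/C(C)=C/CC1Cc2c(OC(=O)Nc3cccc(F)c3)cc(=O)n(CCCO)c2CC1(C)C` — 52.3%

In a functional assay on PANC-1 cells (Homo sapiens) for inhibition, read by MTT assay, with a stated time of 24 h, tested at 10 uM (a lower number here means less inhibition, a higher number more inhibition at the concentration tested (going by the name of the read-out)), compound 3 gives the highest of the three numbers, with compound 2 near it at 47% and compound 1 furthest at 25.2%. Its gap to compound 2, a number 5.3 percentage points higher from compound 2 to compound 3 (within the scatter), lies within the scatter, while the change from the longer chain on the oxygen was larger: a number 27.1 percentage points higher from compound 1 to compound 3 (beyond the scatter) and a number 21.8 percentage points higher from compound 1 to compound 2 (beyond the scatter).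

Compound 4 `CC(C)=CCC/C(C)=C/CC1Cc2c(OC(=O)Nc3cccc(C(F)(F)F)c3)cc(=O)n(CCCO)c2CC1(C)C` differs from compound 3 in one place: trifluoromethyl in place of fluoro on an aromatic carbon. Among the compounds with values here, the only step that bears on this change is the swap of groups on the same aromatic carbon, a number 5.3 percentage points higher from compound 2 to compound 3 (within the scatter), which stayed within the scatter. Compound 4 is therefore expected to show no step beyond the scatter in this assay, a number 2.3 percentage points lower from compound 3 to compound 4 (within the scatter). Compound 4 is estimated at 50%, between 36% and 64%.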

Compound 4, a percentage reported as inhibition, at one concentration (the size of the read-out at that concentration, not a potency): 44%
Compound 4: the middle estimate sits 6 percentage points above what was measured; low and high end bracket the measured number.
By their numbers in this assay, from the lowest: compound 1; then compounds 4, 2 and 3 (each within the scatter of the next).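

On the aromatic carbon of the carbamoyl phenyl group, the result adds trifluoromethyl to fluoro and methoxy, with a number 8.3 percentage points lower from compound 3 to compound 4 (within the scatter) and a number 3 percentage points lower from compound 2 to compound 4 (within the scatter) in this assay as the steps. Replacing one heavy atom with four at this place thus gave no step beyond the scatter, and all three groups stay within the scatter of each other. Nothing measured here gives a reason for this result.

On these data alone, whether an amine or a carboxylic acid on this carbon would give a step beyond the scatter remains open. So does whether trifluoromethyl would read the same on another carbon of the ring.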